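This account rests on a few compounds, and the source may have more. Where it says the series, first, only, none or still open, it means among the compounds named here.

Measured so far in a functional assay on Huh-7 cells (Homo sapiens) for cytotoxicity, read by CCK-8 assay, with a stated time of 72 h; on this read-out lower numbers stand for stronger inhibition and higher numbers for weaker inhibition: compound 1 `C=CCn1c(=O)/c(=C\c2cccc(Cl)c2)[nH]c(=O)/c1=C\c1ccccc1OC`, 8900 nM; compound 2 `C=CCn1c(=O)/c(=C\c2ccccc2OC)[nH]c(=O)/c1=C\c1ccccc1OC`, 21200 nM; compound 3 `C=CCn1c(=O)/c(=C\c2ccccc2C(F)(F)F)[nH]c(=O)/c1=C\c1ccccc1OC`, 9500 nM.

Compound 3 stands second highest of the three numbers in this assay; the gap a 1.1-fold higher number from compound 1 to compound 3 (0.03 log units; within the scatter) lies within the scatter, while the gap a 2.2-fold lower number from compound 2 to compound 3 (0.35 log units; beyond the scatter) is modest. Going by the values given here, the step to compound 1 from compound 2, a 2.4-fold higher number from compound 1 to compound 2 (0.38 log units; beyond the scatter), is the only other aryl exchange seen. Compound 4 `C=CCn1c(=O)/c(=C\c2ccc(C)cc2)[nH]c(=O)/c1=C\c1ccccc1OC` carries the change (4-methylphenyl in place of 2-(trifluoromethyl)phenyl on a double-bonded chain carbon bound to an aromatic carbon). Among the compounds with values here, no measured step introduces 4-methylphenyl at this position, so only the overall spread of the three aryl swaps guides the expectation: every exchange so far moved the number within the scatter or modestly. For compound 4 a step of a 1.3-fold higher number from compound 3 to compound 4 (0.10 log units; within the scatter) in this assay is expected, not clearly beyond the scatter. Compound 4 is estimated at 12000 nM, range 5000 nM to 30000 nM.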

Compound 4, half-maximal inhibitory concentration: "not active" (no number reported)
Nothing numeric was reported for compound 4; no gap can be computed for the estimate.
By their numbers in this assay, from the lowest: compounds 1 and 3 (each within the scatter of the next); then compound 2.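

In this assay, going by these compounds alone, compound 4 is recorded as "not active" with no number, so no step from compound 3 to compound 4 can be read. The compounds shown leave open how far 4-methylphenyl in place of 2-(trifluoromethyl)phenyl moves the number, and no supporting data bear on this result.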